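Demethylating the Piperazine Urea of Compound 2

The compounds below may be only part of what the source reports. "The series", "measured", "known", "first", "only" and "open" are said of these compounds alone.

Among the compounds with values here, compound 2 `COc1cc(O)c2c(=O)cc(-c3ccc(NC(=O)N4CCN(C)CC4)cc3)oc2c1OC(C)C` gives 12500 nM in a functional assay on DU-145 cells (Homo sapiens) for antiproliferative activity, read by MTT assay, with a stated time of 3 days (a higher number here means a weaker inhibitor, a lower number a stronger inhibitor), the lowest of the two numbers so far; its nearest neighbour, compound 1 `COc1cc(O)c2c(=O)cc(-c3ccc(NC(=O)NC4CC4)cc3)oc2c1OC(C)C`, gives 15600 nM, and a 1.2-fold lower number from compound 1 to compound 2 (0.10 log units; within the scatter). Compound 3 `COc1cc(O)c2c(=O)cc(-c3ccc(NC(=O)N4CCNCC4)cc3)oc2c1OC(C)C` differs from compound 2 by hydrogen in place of methyl on an amine nitrogen in a ring. Within the data shown here, no measured step touches this ring nitrogen. Among the measured compounds shown here, the one step available, a 1.2-fold lower number from compound 1 to compound 2 (0.10 log units; within the scatter), replaced the whole amine end of the urea without leaving the scatter. For compound 3 no step beyond the scatter is therefore expected in this assay, no change at the digits printed from compound 2 to compound 3 (within the scatter). Compound 3 is estimated at 12500 nM, ranging from 5000 nM to 31000 nM.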

Compound 3, half-maximal inhibitory concentration: 8000 nM
Compound 3: the middle estimate sits 1.6-fold (0.19 log units) above what was measured; the range from low to high includes it.
By their numbers in this assay, from the lowest: compounds 3, 2 and 1 (each within the scatter of the next).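

In this assay, within the data shown here, the first step at this ring nitrogen, hydrogen in place of methyl, gives a 1.6-fold lower number from compound 2 to compound 3 (0.19 log units; within the scatter), so methyl and hydrogen at this position cannot be told apart here. The wider change on the carbonyl carbon gives a 2.0-fold lower number from compound 1 to compound 3 (0.29 log units; within the scatter), so the three amine ends shown also remain within the scatter of each other. No supporting evidence bears on this result. As far as these compounds go, whether an acetyl group or a longer alkyl chain on this nitrogen, or a morpholine ring in place of the piperazine, would move the number beyond the scatter remains open.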